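The source may report more compounds than this note shows. Statements on the series, on what has been measured and on what is new or still open speak of the compounds shown alone.

Working notes on the series, read in a physicochemical assay for lipophilicity; a higher number here means a more lipophilic compound, a lower number a more polar compound. For the measured compounds named here, compound 1 `CCCCCCN(CCCCCSc1nc2ccccc2s1)C(=O)Nc1ccc(F)cc1F` gives 7.78, and compound 2 `CCCCCCN(CCCCCSc1nc2cc([N+](=O)[O-])ccc2[nH]1)C(=O)Nc1ccc(F)cc1F` gives 7.19, the lower of the two numbers so far. Compound 3 `CCCCCCN(CCCCCSc1nc2ccc[nH]c-2n1)C(=O)Nc1ccc(F)cc1F` has yet to be measured in this assay.

The change leading to compound 3 is a group of 9 heavy atoms (6 carbon, 3 nitrogen; one five-membered aromatic ring with 2 hetero atoms, one six-membered aromatic ring with 1 hetero atom) in place of a group of 12 heavy atoms (7 carbon, 3 nitrogen, 2 oxygen; one five-membered aromatic ring with 2 hetero atoms, one six-membered aromatic ring of carbon only), on a sulfur. The entering group holds no oxygen, and its six-membered aromatic ring carries a hetero atom.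

Going by the values given here, only one measured step bears on this: a number 0.59 log units lower from compound 1 to compound 2 (beyond the scatter). It also exchanged the group on the sulfur, but for a different pair of groups. Among the compounds with values here, one step is thin support, and no measured compound carries the entering group. The direction therefore rests on the counted change, with fewer carbon atoms in the entering group, and a further modest drop of similar size is expected, though a result closer to compound 2 remains possible.

The expected change is a number 0.59 log units lower from compound 2 to compound 3 (beyond the scatter). For compound 3 the estimated value is 6.6, with an expected range of 6.1 to 7.1.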

Compound 3, partition coefficient: 6.22
Compound 3: middle estimate off by 0.38 log units, on the high side; the measured number falls inside the stated range.
By their numbers in this assay, from the lowest: compound 3; then compound 2; then compound 1.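

In this assay, the group on the sulfur moves the number further than the first step showed: a number 0.97 log units lower from compound 2 to compound 3 (beyond the scatter), and over the whole set a number 1.56 log units lower from compound 1 to compound 3 (beyond the scatter). Heavy-atom count does not order these three compounds, since the groups of compound 1 and compound 3 have the same count yet stand at the two ends, while the larger group of compound 2 stands in the middle. Nothing available gives a measured reason for the size of either step.

From the compounds shown here alone, the step from compound 2 to compound 3 changes the five-membered-ring and six-membered-ring group and removes the nitro substituent at once, and the share of each change stays open; a plain 1H-benzimidazol-2-yl group on the same sulfur would separate them. Going by these compounds, it also remains open whether the number would keep falling with an amino or carboxylic acid substituent on the group of compound 3, or whether a longer chain in place of the hexyl chain would shift all three numbers alike.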